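Sulfonyl aryl variation: from phenyl to 3,4-difluorophenyl

The compounds below may be only part of what the source reports. "The series", "measured", "known", "first", "only" and "open" are said of these compounds alone.

Within the data shown here, compound 2 `CC1CCN(c2c(S(=O)(=O)c3ccccc3)cnc3ccc(Cl)cc23)CC1` stands lowest of the two compounds measured so far in an assay on isolated protein for displacement of a labelled ligand from metabotropic glutamate receptor 5 (Homo sapiens), with a stated time of 60 min, tested at 1 uM (on this read-out lower numbers stand for less inhibition and higher numbers for more inhibition at the one concentration tested (going by the name of the read-out)), where compound 2 gives 59%. Its nearest neighbour is compound 1 `CC1CCN(c2c(S(=O)(=O)c3cccc(Cl)c3)cnc3ccc(Cl)cc23)CC1`, which in this assay gives 92%. Among the measured compounds shown here, the one step measured between them, a number 33 percentage points lower from compound 1 to compound 2 (beyond the scatter), shows that removing a halogen from the aryl ring on the sulfonyl sulfur lowers the read-out well beyond the scatter.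

Compound 3 `CC1CCN(c2c(S(=O)(=O)c3ccc(F)c(F)c3)cnc3ccc(Cl)cc23)CC1` differs from compound 2 in one place: 3,4-difluorophenyl in place of phenyl on a sulfonyl sulfur. This change runs in the opposite sense to the measured step, since it puts halogens back onto the aryl ring on the sulfonyl sulfur, though as two fluorines rather than one chloro. For the measured compounds named here, the single step that bears on it was large, so a rise beyond the scatter is expected, a number 21 percentage points higher from compound 2 to compound 3 (beyond the scatter), though its size is uncertain with only one step to go on. For compound 3 in this assay the estimate is 80%, within a range of 60% to 95%.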

Compound 3, a percentage reported as inhibition, at one concentration (the size of the read-out at that concentration, not a potency): 72%
Beside the measured number, compound 3's estimate is 8 percentage points above it, and the stated range covers the measured number.
By their numbers in this assay, from the lowest: compound 2; then compound 3; then compound 1.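

Halogen on the aryl ring at the sulfonyl sulfur now appears in two forms, and 3,4-difluorophenyl in place of phenyl gives a number 13 percentage points higher from compound 2 to compound 3 (beyond the scatter) in this assay so the gain over phenyl is not confined to 3-chlorophenyl. The two halogenated rings are not equivalent either: 3,4-difluorophenyl in place of 3-chlorophenyl gives a number 20 percentage points lower from compound 1 to compound 3 (beyond the scatter) and compound 1 keeps the highest number of the three. No measurement at hand accounts for either difference.

Compound 1 and compound 3 differ in both the kind and the number of halogens on this ring, so the two cannot be separated here. Going by these compounds, whether a methoxy group or a nitrile on the phenyl ring would match 3-chlorophenyl remains open.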